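The source may report more compounds than this note shows. Statements on the series, on what has been measured and on what is new or still open speak of the compounds shown alone.

The first three compounds give a rough frame for judging a new one. In a functional assay on MCF7 cells (Homo sapiens) for inhibition, read by CCK-8 assay, with a stated time of 48 h (a higher number here means a weaker inhibitor of growth, a lower number a stronger inhibitor of growth), compound 1 `Cc1ccccc1Nc1nc(NC2CCCCC2)ncc1Cl` returns only a limit, > 100000 nM, and not a number. Two compounds do give numbers. Compound 2 `Cc1ccccc1Nc1nc(Nc2ccc(N3CCCN(C)CC3)cc2)ncc1Cl` gives 4290 nM, and compound 3 `COc1ccc(CNc2nc(Nc3ccc(N4CCN(C)CC4)cn3)ncc2Cl)cc1` gives 17300 nM. Compound 3 therefore has the higher of the two numbers, meaning the weaker growth inhibition, and the gap between them lies beyond the usual scatter.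

Compound 4 `CC(C)c1ccc(Nc2nc(Nc3ccc(N4CCN(C)CC4)cn3)ncc2Cl)cc1` has not yet been measured. It differs from compound 3 in one place, with 4-isopropylphenyl in place of 4-methoxybenzyl on a nitrogen on an aromatic ring.

Among the measured compounds shown here, no measured pair of compounds isolates this change, so any forecast is loose. The best available guide is compound 2, which also has a substituted phenyl group on that nitrogen, not a benzyl group, and gives 4290 nM. That points to a modest move towards a lower number in this assay, close to the edge of the usual scatter. The expected step is a 2.2-fold lower number from compound 3 to compound 4 (0.33 log units; beyond the scatter). For compound 4 the estimated value is 8000 nM, with an expected range from 2500 nM to 30000 nM.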

Compound 4, concentration for 50% growth inhibition: 1880 nM
Compound 4: the middle estimate sits 4.3-fold (0.63 log units) above what was measured; the measured number lies below the stated range.
By their numbers in this assay, from the lowest: compound 4; then compound 2; then compound 3. At a limit, above all of these: compound 1.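

Replacing 4-methoxybenzyl with 4-isopropylphenyl on this nitrogen gives a 9.2-fold lower number from compound 3 to compound 4 (0.96 log units; beyond the scatter) in this assay, so growth inhibition here depends clearly on which group the nitrogen carries. The two groups have the same count of heavy atoms and each holds one six-membered aromatic ring of carbon only, so the difference in the numbers does not follow the size of the group as counted in heavy atoms; what does differ is that the oxygen of the methoxy group leaves, and the ring in compound 4 sits directly on the nitrogen, not one carbon further out. Nothing measured here explains why this change lowers the number.

This single step changes the link to the ring and the group on the ring together, so it cannot say how much each contributes, and 4-methoxyphenyl or 4-isopropylbenzyl on the same nitrogen would be needed to separate the two. The compounds shown also leave open how this position would respond to a group carrying an amine or a carboxylic acid on the ring.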